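This account rests on a few compounds, and the source may have more. Where it says the series, first, only, none or still open, it means among the compounds named here.

Measured so far in an ADME assay on CEM-SS cells (Homo sapiens) for cytotoxicity, read by XTT assay, with a stated time of 6 days; a lower number here means that less compound is tolerated, a higher number that more compound is tolerated:

- Compound 1 `CCCC(=O)OCSc1ccccc1C(=O)NCCCCNC(C)=O`: 17.4 uM
- Compound 2 `CCCC(=O)OCSc1ccccc1C(=O)NCCCCCNC(C)=O`: 9.2 uM
- Compound 3 `CCCCCNC(=O)CNC(=O)c1ccccc1SCOC(=O)CCC`: 24.8 uM

Compound 3, at 24.8 uM, cannot be separated from its nearest neighbour, as the record shows a 1.4-fold higher number from compound 1 to compound 3 (0.15 log units; within the scatter). Its furthest neighbour lies outside that range, with a 2.7-fold higher number from compound 2 to compound 3 (0.43 log units; beyond the scatter).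

The next compound is compound 4 `CCCC(=O)OCSc1ccccc1C(=O)NCC(=O)NCC(=O)OC`. The change is methoxycarbonyl in place of butyl on a saturated chain carbon bound to an amide-type nitrogen, in words methoxycarbonyl in place of butyl on a saturated chain carbon bound to an amide-type nitrogen. For the measured compounds named here, no measured step makes this exact exchange. The nearest guides are the other changes in the chain attached to the amide-type nitrogen. These are a 1.9-fold lower number from compound 1 to compound 2 (0.28 log units; within the scatter), a 1.4-fold higher number from compound 1 to compound 3 (0.15 log units; within the scatter) and a 2.7-fold higher number from compound 2 to compound 3 (0.43 log units; beyond the scatter). Only the last lies beyond the scatter, and it is modest. None of these steps introduces an ester-bearing chain end, so the data give no direction for the new group.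

In this assay, a step no larger than those is therefore expected, most likely none beyond the scatter. The estimate amounts to an expected 1.1-fold lower number from compound 3 to compound 4 (0.05 log units; within the scatter). For compound 4 the estimated value is 22 uM, with an expected range of 9 uM to 55 uM.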

Compound 4, half-maximal toxic concentration: > 100 uM
Compound 4: a limit, no number; the forecaster's own chance of this, stated with the estimate: 10%; middle value at least 4.5-fold (0.65 log units) from the limit.
By their numbers in this assay, from the lowest: compounds 2, 1 and 3 (each within the scatter of the next, the first and the last beyond it). At a limit, above all of these: compound 4.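

In this assay compound 4 stands at a limit and not at a number: the limit of > 100 uM in this assay, at which 1 of the 4 values shown sits. Methoxycarbonyl in place of butyl on a saturated chain carbon bound to an amide-type nitrogen gives an at least 4.0-fold higher number from compound 3 to compound 4 (0.60 log units; beyond the scatter), and the wider comparisons with the two acetamido-ended chains give an at least 5.7-fold higher number from compound 1 to compound 4 (0.75 log units; beyond the scatter) and an at least 10-fold higher number from compound 2 to compound 4 (1.03 log units; beyond the scatter). Among compounds 1, 2 and 3 the changes at this chain produced at most a modest step, whereas these results show that the chain end can move the tolerated concentration much further, with the methoxycarbonyl end lying beyond the scatter from all three.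

The compounds shown do not tell whether this step belongs to the methyl ester itself or would also appear with another chain end, such as a carboxylic acid, a primary amide or an ethyl ester. They also leave open whether a longer chain between the amide-type nitrogen and the ester would keep compound 4's place, and whether the same exchange would behave alike with a group other than the butanoyloxymethyl thioether on the shared core.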